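The compounds below may be only part of what the source reports. "The series", "measured", "known", "first", "only" and "open" are said of these compounds alone.

Measured compounds in a functional assay on HeLa cells (Homo sapiens) for antiproliferative activity, read by MTT assay, with a stated time of 48 h; a higher number here means a weaker inhibitor, a lower number a stronger inhibitor: compound 1 `CNCC(=O)Nc1cc(OC)ccc1C(=O)c1ccc2c(c1)C=CC(C)(C)O2` gives 970 nM; compound 2 `CCNCC(=O)Nc1cc(OC)ccc1C(=O)c1ccc2c(c1)C=CC(C)(C)O2` gives 3110 nM; compound 3 `CNCC(=O)Nc1cc(OC)ccc1C(=O)c1cc(OC)c(OC)c(OC)c1` gives 690 nM.

Compound 1 and compound 3 share a side chain but differ in the core; that difference between the two cores is not broken down here. Compound 3 and compound 1 lie within the scatter of each other in this assay.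

One change is followed twice. On the core of compound 1 it reads methyl in place of hydrogen on a saturated chain carbon bound to an amine nitrogen and gave a 3.2-fold higher number from compound 1 to compound 2 (0.51 log units; beyond the scatter).

Compound 4 `CCNCC(=O)Nc1cc(OC)ccc1C(=O)c1cc(OC)c(OC)c(OC)c1` is not yet measured; it carries the same change on the core of compound 3, (methyl in place of hydrogen on a saturated chain carbon bound to an amine nitrogen). Among the measured compounds shown here, a step of about the same size is expected, a 3.2-fold higher number from compound 3 to compound 4 (0.50 log units; beyond the scatter), because the single precedent was a 3.2-fold higher number from compound 1 to compound 2 (0.51 log units; beyond the scatter). On that basis compound 4 is estimated at 2200 nM in this assay.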

Compound 4, half-maximal inhibitory concentration: 2100 nM
Compound 4: the middle estimate sits 1.0-fold (0.02 log units) above what was measured, and the stated range covers the measured number.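

In this assay, the change from methylamino to ethylamino gave a 3.0-fold higher number from compound 3 to compound 4 (0.48 log units; beyond the scatter), a step in the same direction as the one seen on the core of compound 1. The two steps agree in size: the same change on two cores in this assay, a 3.2-fold higher number (0.51 log units; beyond the scatter) from compound 1 to compound 2 and a 3.0-fold higher number (0.48 log units; beyond the scatter) from compound 3 to compound 4, 1.1-fold (0.02 log units) apart, within the scatter of two such steps. This shows the change carrying over between these two cores in this assay, but two pairs set no rule for other cores and do not show why the number rises.

Still open, on these data alone, is whether a longer chain such as propylamino, a branched group such as isopropylamino, or a primary amine would continue the same trend on either core. Also open, as far as these compounds go, is whether the step would hold on a third core or in another assay.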